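The source may report more compounds than this note shows. Statements on the series, on what has been measured and on what is new or still open speak of the compounds shown alone.

Values in an ADME assay on MDBK cells (Bos taurus) for cytotoxicity, read by MTT assay, with a stated time of 96 h; on this read-out higher numbers stand for lower toxicity in this test and lower numbers for higher toxicity in this test:

- Compound 1 `CN(C)CCCN(/N=N/c1ccccc1)c1cccc(C(F)(F)F)c1`: 38000 nM
- Compound 2 `CN(C)CCCN(/N=N/c1ccccc1)c1ccccc1`: 95000 nM
- Compound 3 `CN(C)CCCN(/N=N/c1cc(F)ccc1F)c1cccc(C(F)(F)F)c1`: > 100000 nM

The value for compound 3 is a limit of the assay and not a number. Among the measured compounds shown here, only two exact numbers are therefore available, and compound 1 has the lower one, at 38000 nM. On this read-out, that points to higher toxicity in this test.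

Compound 4 `FC(F)(F)c1cccc(N(C[C@@H]2CCCN3CCCC[C@H]23)/N=N/c2ccccc2)c1` keeps the core of compound 1 but changes its side chain: a group of 10 heavy atoms (9 carbon, 1 nitrogen; 2 six-membered non-aromatic rings with 1 hetero atom each) in place of a group of 5 heavy atoms (4 carbon, 1 nitrogen; no ring), on a saturated chain carbon bound to a nitrogen on an aromatic ring.

Two measured steps start from compound 1. Hydrogen in place of trifluoromethyl on an aromatic carbon gave a 2.5-fold higher number from compound 1 to compound 2 (0.40 log units; beyond the scatter). Placing 2,5-difluorophenyl in place of phenyl on a double-bonded nitrogen gave an at least 2.6-fold higher number from compound 1 to compound 3 (0.42 log units; beyond the scatter). Both steps are modest and both raise the number, but neither touches the side chain, so they offer only a rough guide to size. For the measured compounds named here, no measured compound carries the entering group, which leaves the direction uncertain. A modest step is expected, with a slight lean towards a lower number in this assay. The estimated change is a 1.9-fold lower number from compound 1 to compound 4 (0.28 log units; within the scatter). For compound 4, the expected value is 20000 nM, within an estimated range of 6000 nM to 60000 nM.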

Compound 4, half-maximal cytotoxic concentration: 22000 nM
Compound 4: middle estimate off by 1.1-fold (0.04 log units), on the low side, within the range that was stated.
By their numbers in this assay, from the lowest: compounds 4 and 1 (each within the scatter of the next); then compound 2. At a limit, above all of these: compound 3.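

Compound 4 is the first compound shown with a change in the side chain, and in this assay the exchange gives a 1.7-fold lower number from compound 1 to compound 4 (0.24 log units; within the scatter). The printed size of that step sets it apart from the exchange of trifluoromethyl for hydrogen on the aromatic carbon, a 2.5-fold higher number from compound 1 to compound 2 (0.40 log units; beyond the scatter), so this one comparison shows that a group of 10 heavy atoms with 2 six-membered non-aromatic rings can replace 2-(dimethylamino)ethyl, a group of 5 heavy atoms with no ring, without moving the read-out beyond the scatter. Both groups count 0 hydrogen-bond donors and 1 hydrogen-bond acceptor, and no measured property among the data shown speaks to why the two values stay so close.

As far as these compounds go, a single exchange cannot separate the added rings from the 2 defined stereocentres that enter with them, so the part played by each remains open. Also open, from the compounds shown here alone, is whether a longer chain, or a side chain ending in a carboxylic acid in place of the amine, would stay within the scatter of compound 1 or move clearly away from it.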